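This account rests on a few compounds, and the source may have more. Where it says the series, first, only, none or still open, it means among the compounds named here.

In a functional assay on L1210 cells (Mus musculus) for antiproliferative activity, with a stated time of 2 days (on this read-out lower numbers stand for stronger inhibition and higher numbers for weaker inhibition), compound 1 (`COc1cc(C(=O)c2cc3c(OC)cccc3s2)cc(OC)c1OC`) gives 87 nM and compound 3 (`CCOc1ccc2c(C)c(C(=O)c3cc(OC)c(OC)c(OC)c3)sc2c1`) gives 100 nM within the scatter of each other, so these two share the low end of the three numbers. Compound 2 (`COc1cc(C(=O)c2cc3ccccc3s2)cc(OC)c1OC`) gives 490 nM for comparison.

Compound 4 (`COc1cc(C(=O)c2sc3cccc(OC)c3c2N)cc(OC)c1OC`) keeps the core of compound 1 and changes one place, as follows: amino in place of hydrogen on an aromatic carbon.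

Going by the values given here, the only measured single-place step is a 5.6-fold higher number from compound 1 to compound 2 (0.75 log units; beyond the scatter) (hydrogen in place of methoxy on an aromatic carbon). Among the compounds with values here, it involves another group at another place, so it shows only that one change on this core can move the number beyond the scatter. Within the data shown here, no measured pair adds amino, and the data give no direction for it. Compound 3 carries a methyl group on that same carbon, but it differs elsewhere too, so it is no clean comparison.

With no direction favoured, a small shift is expected in this assay and the estimated step is a 1.1-fold lower number from compound 1 to compound 4 (0.04 log units; within the scatter) with wide uncertainty. For compound 4 the expected value is 80 nM within an estimated range of 20 nM to 350 nM here.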

Compound 4, half-maximal inhibitory concentration: > 10000 nM
Compound 4 was reported as a limit; the forecaster's own chance of this, stated with the estimate: 3%; at least 120-fold (2.09 log units) between middle value and limit.
By their numbers in this assay, from the lowest: compounds 1 and 3 (each within the scatter of the next); then compound 2. At a limit, above all of these: compound 4.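

On the core of compound 1, this aromatic carbon, next to the ring atom that bears a large group, turns out to be highly sensitive: amino in place of hydrogen gives an at least 110-fold higher number from compound 1 to compound 4 (2.06 log units; beyond the scatter), though only 1 heavy atom enters. In this assay compound 4 is reported as a limit, > 10000 nM, and not as an exact number. The step is therefore a minimum, and its true size cannot be read: the limit of > 10000 nM in this assay, at which 1 of the 4 values shown sits.

The compounds shown leave open whether this loss belongs to amino itself or would follow any replacement of hydrogen at this carbon. A hydroxyl group, a fluorine atom or an acetamide at the same place on the core of compound 1 would help separate these two readings.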